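The source may hold more compounds than are shown below. What is called first, only, known or untested is meant among the compounds shown, and "the series" means these compounds.

Three compounds have been measured in an assay on isolated protein for binding affinity to adenosine receptor A1 (Bos taurus); on this read-out higher numbers stand for weaker inhibition and lower numbers for stronger inhibition:

Compound 1 `CNc1nc(-c2ccccc2)nc2c1nnn2Cc1ccccc1Cl` gives 191000000 nM.
Compound 2 `OCCCNc1nc(-c2ccccc2)nc2c1nnn2Cc1ccccc1F` gives 3700000 nM.
Compound 3 `Clc1ccccc1Cn1nnc2c(NC3CCCCC3)nc(-c3ccccc3)nc21` gives 34000000 nM.

Compound 3 stands second highest of the three, reached by a 5.6-fold lower number from compound 1 to compound 3 (0.75 log units; beyond the scatter), while compound 2 shows a lower number than compound 3. Compound 4 `OCCCNc1nc(-c2ccccc2)nc2c1nnn2Cc1ccccc1Cl` differs from compound 3 by 3-hydroxypropyl in place of cyclohexyl on a nitrogen on an aromatic ring. Within the data shown here, the one step that bears on this change is a 5.6-fold lower number from compound 1 to compound 3 (0.75 log units; beyond the scatter), a modest change of the group on the same nitrogen. Compound 2 carries the same 3-hydroxypropylamino group and gives 3700000 nM in this assay, the rest of its structure differing only slightly from compound 4. Compound 4 is therefore expected to give a lower number than compound 3, estimated at 5000000 nM with a range from 1500000 nM to 20000000 nM, meaning a 6.8-fold lower number from compound 3 to compound 4 (0.83 log units; beyond the scatter).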

Compound 4, inhibition constant: 33000000 nM
For compound 4 the middle estimate is 6.6-fold (0.82 log units) below the measured one, and the stated range ends below it.
By their numbers in this assay, from the lowest: compound 2; then compounds 4 and 3 (each within the scatter of the next); then compound 1.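

In this assay, cyclohexyl and 3-hydroxypropyl on this nitrogen cannot be told apart (a 1.0-fold lower number from compound 3 to compound 4 (0.01 log units; within the scatter)), and both differ from methyl (a 5.6-fold lower number from compound 1 to compound 3 (0.75 log units; beyond the scatter); a 5.8-fold lower number from compound 1 to compound 4 (0.76 log units; beyond the scatter)). With 3-hydroxypropyl held fixed, chloro in place of fluoro on an aromatic carbon accounts for the gap (an 8.9-fold higher number from compound 2 to compound 4 (0.95 log units; beyond the scatter)), so among these compounds the lower number of compound 2 goes with the fluoro, not with the chain. From the compounds shown here alone, whether a longer chain or a terminal amine on this nitrogen would match these values, and whether fluoro has the same effect alongside cyclohexyl, stays open. No measurement offered here explains these steps.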